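The source may report more compounds than this note shows. Statements on the series, on what has been measured and on what is new or still open speak of the compounds shown alone.

Three compounds sharing one core were measured in an assay on CHO cells for displacement of a labelled ligand from adenosine receptor A1 (Homo sapiens), read by scintillation counting, with a stated time of 120 min, tested at 1 uM; on this read-out higher numbers stand for more inhibition at the one concentration tested (going by the name of the read-out) and lower numbers for less inhibition. Compound 1 `Cc1nc2sc(-c3ccccc3)nc2c(=O)[nH]1` gives 11%. Compound 2 `Cc1ccc(-c2nc3c(=O)[nH]c(C)nc3s2)cc1`, which carries a methyl in place of hydrogen on an aromatic carbon, gives 17%, and compound 3 `Cc1nc2sc(-c3ccc(O)cc3)nc2c(=O)[nH]1`, which carries a hydroxy in place of hydrogen on an aromatic carbon, gives 1%. Compound 1 stands second highest of these three numbers, yet its steps to both other compounds stay within the scatter: a number 6 percentage points higher from compound 1 to compound 2 (within the scatter) and a number 10 percentage points lower from compound 1 to compound 3 (within the scatter). Within the data shown here, the only step beyond the scatter is a number 16 percentage points lower from compound 2 to compound 3 (beyond the scatter).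

Compound 4 `Cc1nc2sc(-c3cccc(Cl)c3)nc2c(=O)[nH]1` has not yet been measured in this assay. It differs from compound 1 in one place: chloro in place of hydrogen on an aromatic carbon. The two measured steps that bear on this change are the ones in which a hydrogen on an aromatic carbon was exchanged for another group, and both stayed within the scatter. Among the measured compounds shown here, neither involves a chloro group, so nothing among the measured compounds points to a step in one direction rather than the other. The expected step is therefore a number 1 percentage points higher from compound 1 to compound 4 (within the scatter), which is not beyond the scatter. Compound 4 is estimated at 12%, with a likely range from 0% to 28%.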

Compound 4, a percentage reported as inhibition, at one concentration (the size of the read-out at that concentration, not a potency): 24%
Compound 4: the middle estimate sits 12 percentage points below what was measured; the measured number falls inside the stated range.
By their numbers in this assay, from the lowest: compounds 3, 1, 2 and 4 (each within the scatter of the next, the first and the last beyond it).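

In this assay, chloro in place of hydrogen on an aromatic carbon, meta to a large group, produces the first step away from compound 1 that clears the scatter, a number 13 percentage points higher from compound 1 to compound 4 (beyond the scatter), and it is a modest one. The two earlier exchanges of a hydrogen on an aromatic carbon gave only a number 6 percentage points higher from compound 1 to compound 2 (within the scatter) and a number 10 percentage points lower from compound 1 to compound 3 (within the scatter), so they could not show that such a replacement moves the number at all, whereas this one does. Nothing among the available data explains why this change gives this result.

The compounds shown leave open whether the rise belongs to the chloro group itself or to where it sits, as chloro appears at only one place on the ring, and a chloro on another carbon of that ring could separate the two. They also leave open what bromine, a methoxy group or an amine would give at this same place, and whether any such change would raise the number further, as each figure here is a single reading at one concentration and not a potency.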